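The source may report more compounds than this note shows. Statements on the series, on what has been measured and on what is new or still open speak of the compounds shown alone.

For the measured compounds named here, compound 1 `Cc1cc(Nc2cc(-c3ccccc3)[nH]n2)n2nc(SCc3ccc(Br)cc3)nc2n1` holds the only number among the values shown in an ADME assay on GES1 cells (Homo sapiens) for inhibition, read by MTT assay, with a stated time of 72 h; a lower number here means a stronger inhibitor, a higher number a weaker inhibitor: compound 1 gives 39300 nM. Compound 2 `Cc1cc(Nc2cc(C(C)(C)C)[nH]n2)n2nc(SCc3ccc(Br)cc3)nc2n1` is recorded in this assay only as a limit, and compound 2 gives > 50000 nM. Going by the values given here, the single measured step, an at least 1.2-fold higher number from compound 1 to compound 2 (0.10 log units; that floor lies within the scatter), puts tert-butyl in place of phenyl on an aromatic carbon and ends at the limit of > 50000 nM in this assay, at which 1 of the 2 values shown sits. Compound 3 `COc1ccc(CSc2nc3nc(C)cc(Nc4cc(-c5ccccc5)[nH]n4)n3n2)cc1` differs from compound 1 elsewhere in the molecule: methoxy in place of bromo on an aromatic carbon. The step from compound 1 to compound 2 changes a different part of the structure than the (4-bromobenzyl)sulfanyl group, so it does not bear on this change, and nothing among the numbers shown gives a direction for swapping bromo for methoxy. The expectation is therefore a step of a 1.0-fold higher number from compound 1 to compound 3 (0.01 log units; within the scatter) in this assay, within the scatter, with a real chance that compound 3 is reported only as a limit. Compound 3 is estimated in this assay at 40000 nM, with a range from 15000 nM to 50000 nM.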

Compound 3, half-maximal inhibitory concentration: 28200 nM
The estimate for compound 3 lay 1.4-fold (0.15 log units) above the measured number; low and high end bracket the measured number.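

In this assay, exchanging bromo for methoxy on the benzyl ring gives a 1.4-fold lower number from compound 1 to compound 3 (0.14 log units; within the scatter), so this position now has a measured step rather than no indication of direction. The change adds one heavy atom and one hydrogen-bond acceptor, yet the numbers for these two compounds cannot be told apart in this assay, and for this pair of groups the position shows no effect that stands clear of the scatter. None of the data shown offers a reason for the size of this step.

With only bromo and methoxy shown at this position, it remains open whether an amine, a carboxylic acid or a longer alkoxy chain in the same place would also leave the number within the scatter of compound 1. On these data alone, it also remains open how the (4-methoxybenzyl)sulfanyl group would behave with tert-butyl in place of phenyl, since the step towards that group ends at a limit and is read only from the bromo series.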